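The source may hold more compounds than are shown below. What is called first, only, known or untested is meant among the compounds shown, and "the series" means these compounds.

compound 1 `CC(=O)Nc1cc(-c2ccc(OC[C@@](C)(N)CC(C)C)c(F)c2)ccn1` gives 70%
compound 2 `CC(=O)Nc1cc(-c2cc(F)c(OC[C@@H](N)CC(C)C)c(F)c2)ccn1` gives 90%
compound 3 `CC(=O)Nc1cc(-c2ccc(OC[C@@H](N)CC(C)C)c(F)c2)ccn1` gives 79%

All three values come from an ADME assay on microsomes from liver (Mus musculus) for metabolic stability, read by LC-MS, using NADPH, with a stated time of 10 min, tested at 0.5 uM (on this read-out lower numbers stand for a less stable compound and higher numbers for a more stable compound), and are read on that scale. Compound 1 (70%) lies within the scatter of compound 3 (79%) and shows a lower number than compound 2 (90%).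

Compound 4 `COC(=O)Nc1cc(-c2ccc(OC[C@@](C)(N)CC(C)C)c(F)c2)ccn1` keeps the core of compound 1 and differs in one place: methoxy in place of methyl on a carbonyl carbon (methoxy in place of methyl on a carbonyl carbon, or acetamido to (methoxycarbonyl)amino).

Neither measured step touches that carbonyl. The step of a number 11 percentage points lower from compound 2 to compound 3 (beyond the scatter) puts hydrogen in place of fluoro on an aromatic carbon, and the step of a number 9 percentage points higher from compound 1 to compound 3 (within the scatter) puts 1-amino-3-methylbutyl in place of 1-amino-1,3-dimethylbutyl on a saturated chain carbon. These two steps give only a sense of how large single changes have been in this series. Among the measured compounds shown here, no measured pair covers methoxy in place of methyl, so the expectation starts from compound 1 (70%) and carries a wide range.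

The estimated step is a number 2 percentage points lower from compound 1 to compound 4 (within the scatter) and it is expected to stay within the scatter. Compound 4 is estimated at 68% with an expected range of 52% to 84% in this assay once measured.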

Compound 4, percent of the compound remaining: 71%
Compound 4: middle estimate off by 3 percentage points, on the low side, and the stated range covers the measured number.
By their numbers in this assay, from the lowest: compounds 1, 4 and 3 (each within the scatter of the next); then compound 2.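

In this assay, methoxy in place of methyl on the carbonyl carbon gives a number 1 percentage points higher from compound 1 to compound 4 (within the scatter), so this is the one change at the carbonyl among the compounds shown, and acetamido to (methoxycarbonyl)amino does not separate from the scatter on the core of compound 1. The oxygen that methoxy brings, with its hydrogen-bond acceptor in the count, therefore comes with no read-out difference on this core, which carries the 1-amino-1,3-dimethylbutyl chain, and this position accepts the exchange in this read-out at the single stated time. No measured information is available on what lies behind this outcome.

As far as these compounds go, whether the carbonyl carbon accepts other groups in place of methyl, such as ethoxy, cyclopropyl or a dimethylamino group, remains open, as does any limit on the size of the group there. Also open, from the compounds shown here alone, is whether (methoxycarbonyl)amino gives an equally small step on the core of compound 3, with the 1-amino-3-methylbutyl chain, or on the core of compound 2, with its additional fluoro.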